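The compounds below may be only part of what the source reports. "The series", "measured", "known", "first", "only" and "open" are said of these compounds alone.

Going by the values given here, compound 1 `COc1cc2c(cc1OC)CN(Cc1ccc(OC)c3oc(-c4ccccc4C(F)(F)F)cc13)CC2` is the only compound here with a number: in an in vitro assay on COS-7 cells for displacement of a labelled ligand from Alpha-2B adrenergic receptor (Homo sapiens) (a higher number here means a weaker inhibitor, a lower number a stronger inhibitor), compound 1 gives 949 nM. Compound 2 `CCCNC(=O)c1cccc(-c2cc3c(CN4CCc5cc(OC)c(OC)cc5C4)ccc(OC)c3o2)c1` carries no result in this assay, where compound 2 is recorded as "not determined" (no result reported). Compound 3 `COc1cc2c(cc1OC)CN(Cc1ccc(OC)c3oc(C(=O)NCC(C)(C)N)cc13)CC2` differs from compound 1 in one place ((2-amino-2-methylpropyl)carbamoyl in place of 2-(trifluoromethyl)phenyl on an aromatic carbon). Among the compounds with values here, no step between two measured compounds is known, so the expectation rests only on compound 1 at 949 nM. A step beyond the scatter toward weaker binding, a 3.2-fold higher number from compound 1 to compound 3 (0.50 log units; beyond the scatter), is expected, and the estimate for compound 3 is 3000 nM, within 500 nM to 20000 nM.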

Compound 3, inhibition constant: 1540 nM
For compound 3 the middle estimate is 1.9-fold (0.29 log units) above the measured one; measured number inside the range.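

In this assay, putting (2-amino-2-methylpropyl)carbamoyl in place of 2-(trifluoromethyl)phenyl gives a 1.6-fold higher number from compound 1 to compound 3 (0.21 log units; within the scatter) and so leaves binding indistinguishable from that of compound 1. At this aromatic carbon next to the ring oxygen, an open chain with no ring therefore reads the same as a six-membered aromatic ring of carbon only. Nothing measured here bears on why the two groups read alike. Open, from the compounds shown here alone, is whether the carbonyl or the amine at the chain end matters here; a simple methyl amide, a carboxylic acid or an unsubstituted phenyl ring at this position would help separate these.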